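Swapping the group on the sulfonyl sulfur: compound 2 to compound 3

A few compounds are considered here, and "the series" means these few. Any claim that something is new, unique, unknown or untested is made for them only; others in the source may bear on it.

In a functional assay on HEK293 cells (Homo sapiens) for cytotoxicity (on this read-out higher numbers stand for lower toxicity in this test and lower numbers for higher toxicity in this test), compound 1 (`COc1ccc([C@H]2CC(=O)N(c3cccc(NCCCc4ccccc4)c3)C2)cc1OC1CCCC1`) reads > 10000 nM, which is a limit of the assay and not a number. Compound 2 (`COc1ccc([C@H]2CC(=O)N(c3cccc(NS(=O)(=O)c4c(F)cccc4F)c3)C2)cc1OC1CCCC1`) reads > 10000 nM, and this too is only a limit. Among the compounds with values here, the series so far therefore rests on (the limit of > 10000 nM in this assay, at which 2 of the 2 values shown sit), and compound 2 has no numerical value to start from.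

Compound 3 (`COc1ccc([C@H]2CC(=O)N(c3cccc(NS(=O)(=O)c4ccccc4Br)c3)C2)cc1OC1CCCC1`) differs from compound 2 in one place, on a sulfonyl sulfur whose other neighbour is the sulfonamide nitrogen: 2-bromophenyl in place of 2,6-difluorophenyl on a sulfonyl sulfur. Within the data shown here, the only measured step that bears on this change is a step that the two limits leave unreadable from compound 1 to compound 2, and it offers no size to carry over. It also changes a different group, so it gives no direction either.

In this assay, no shift beyond the usual scatter is expected, and another reading at the limit is the likeliest result. The expected change is a number no higher from compound 2 to compound 3 (the limit leaves the size open), with no direction foreseen. For compound 3 the estimate is 10000 nM, with an expected range from 5000 nM to 20000 nM.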

Compound 3, half-maximal cytotoxic concentration: > 10000 nM
Compound 3: no number, only a limit (the forecaster's own chance of this, stated with the estimate: 85%); the middle value lies on the limit itself.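

In this assay compound 3 reads > 10000 nM and this is a limit of the assay, not a number. No step among compound 1, compound 2 and compound 3 can be read, because all three stand at the same limit: the limit of > 10000 nM in this assay, at which 3 of the 3 values shown sit.

The compounds shown leave open how the groups compared here rank for cytotoxicity, and whether they differ at all.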